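This account rests on a few compounds, and the source may have more. Where it says the series, first, only, none or still open, it means among the compounds named here.

Values in a functional assay on U-87MG ATCC cells for antiproliferative activity against U-87 MG (Homo sapiens), read by MTT assay, with a stated time of 72 h; a lower number here means a stronger inhibitor, a higher number a weaker inhibitor:
compound 1 `O=C(Nc1ccc(Oc2ccnc3[nH]ccc23)c(F)c1)c1cc2cccnc2n(-c2ccccc2)c1=O` — 1260 nM
compound 2 `Cn1ccc2c(Oc3ccc(NC(=O)c4cc5cccnc5n(-c5ccccc5)c4=O)cc3)ccnc21` — 5030 nM
compound 3 `Cn1ccc2c(Oc3ccc(NC(=O)c4cc5cccnc5n(-c5ccc(F)c(Cl)c5)c4=O)cc3)ccnc21` — 2350 nM

Compound 2 gives the highest number of the three; compound 3 lies nearest to it and compound 1 furthest. For the measured compounds named here, the only step measured between compounds that differ in one place, a 2.1-fold lower number from compound 2 to compound 3 (0.33 log units; beyond the scatter), concerns the aryl group on the aromatic nitrogen and not the position now in question. Compound 4 `Cn1ccc2c(Oc3ccc(NC(=O)c4cc5cccnc5n(-c5ccccc5)c4=O)cc3F)ccnc21` differs from compound 2 only by fluoro in place of hydrogen on an aromatic carbon. Going by the values given here, no measured pair isolates this change. Compound 1 carries the same fluoro but lacks the methyl on the ring nitrogen that compound 2 carries, so the two differ in two places; in this assay compound 1 gives a lower number than compound 2, which points, weakly, toward a lower number for compound 4 as well. A modest downward step is therefore expected, a 2.0-fold lower number from compound 2 to compound 4 (0.30 log units; within the scatter), with its size less secure than its direction. Compound 4 is estimated at 2500 nM, within a range from 1000 nM to 6000 nM.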

Compound 4, half-maximal inhibitory concentration: 3590 nM
Beside the measured number, compound 4's estimate is 1.4-fold (0.16 log units) below it; low and high end bracket the measured number.
By their numbers in this assay, from the lowest: compounds 1, 3, 4 and 2 (each within the scatter of the next, the first and the last beyond it).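

In this assay, fluoro in place of hydrogen on an aromatic carbon, ortho to a large group and meta to a large group, can now be read on its own as a 1.4-fold lower number from compound 2 to compound 4 (0.15 log units; within the scatter), so with the methyl kept on the ring nitrogen this change does not separate the two compounds. The other single change, methyl in place of hydrogen on an aromatic nitrogen with the fluoro kept, reads as a 2.8-fold higher number from compound 1 to compound 4 (0.45 log units; beyond the scatter), and of these two steps only this one lies beyond the scatter. Nothing at hand accounts for either step.

From the compounds shown here alone, whether a chloro, methoxy or amine group at this aromatic carbon would shift the number beyond the scatter remains open. Also open, going by these compounds, are how a longer chain such as ethyl would compare with methyl on the ring nitrogen, and whether the methyl step holds with hydrogen in place of the fluoro.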